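The compounds below may be only part of what the source reports. "The series", "measured", "known", "first", "only" and "open" are said of these compounds alone.

Compound 1 `COc1cc(NC(C)CCCNC(=O)Nc2cccc(Cl)c2)c2ncccc2c1` is the starting point. Among the measured compounds shown here, in a functional assay on SW-620 cells (Homo sapiens) for inhibition, read by MTT assay, with a stated time of 72 h (a higher number here means a weaker inhibitor, a lower number a stronger inhibitor), compound 1 gives 26000 nM, the second highest of the three numbers measured so far. Its nearest neighbour is compound 3 `COc1cc(NC(C)CCCNC(=O)Nc2ccc(Cl)cc2)c2ncccc2c1`, which gives 28000 nM; the furthest is compound 2 `COc1cc(NC(C)CCCNC(=O)Nc2cccc(C(F)(F)F)c2)c2ncccc2c1`, which gives 22000 nM. All three sit close together: a 1.2-fold lower number from compound 1 to compound 2 (0.07 log units; within the scatter), a 1.1-fold higher number from compound 1 to compound 3 (0.03 log units; within the scatter) and a 1.3-fold higher number from compound 2 to compound 3 (0.10 log units; within the scatter) are each within the scatter.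

Compound 4 `COc1cc(NC(C)CCCNC(=O)NNC(=O)Nc2cccc(Cl)c2)c2ncccc2c1` differs from compound 1 in one place: ((3-chlorophenyl)carbamoyl)amino in place of 3-chlorophenyl on an amide-type nitrogen. The measured steps only swap substituents on the aromatic ring, so none of them tests an insertion of this kind, and they give no reason to expect a step beyond the scatter. Compound 4 is therefore estimated at 30000 nM, in a range from 10000 nM to 90000 nM, which is expected to mean a 1.2-fold higher number from compound 1 to compound 4 (0.06 log units; within the scatter).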

Compound 4, half-maximal inhibitory concentration: 25000 nM
Compound 4: middle estimate off by 1.2-fold (0.08 log units), on the high side; measured number inside the range.
By their numbers in this assay, from the lowest: compounds 2, 4, 1 and 3 (each within the scatter of the next).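

Placing ((3-chlorophenyl)carbamoyl)amino on this amide-type nitrogen in place of 3-chlorophenyl gives no shift in this assay (a 1.0-fold lower number from compound 1 to compound 4 (0.02 log units; within the scatter)). The comparisons with the other two aryl ureas agree (a 1.1-fold lower number from compound 3 to compound 4 (0.05 log units; within the scatter); a 1.1-fold higher number from compound 2 to compound 4 (0.06 log units; within the scatter)), so this position accepts a larger group with added hydrogen-bond donors, not only swaps on the ring, without leaving the scatter. Nothing measured here bears on why the number holds.

Still open, going by these compounds, is whether an amine or a carboxylic acid on the aromatic ring would move the number beyond the scatter. A longer chain on this nitrogen also remains untested among the compounds shown.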